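The compounds below may be only part of what the source reports. "The series", "measured", "known", "first", "only" and "open" are said of these compounds alone.

Measured so far in a functional assay on HL-60 cells (Homo sapiens) for antiproliferative activity, read by MTT assay, with a stated time of 72 h; a higher number here means a weaker inhibitor, a lower number a stronger inhibitor:
Compound 1 `COc1cc(C(=O)c2sc3ccccc3c2-c2ccc(C)cc2)cc(OC)c1OC`: 1400 nM
Compound 2 `COc1cc(C(=O)c2sc3ccccc3c2Nc2ccc(Cl)cc2)cc(OC)c1OC`: 5400 nM

Compound 2 has the higher number of the pair, which makes it the weaker inhibitor in this assay. Going by the values given here, the only measured step is a 3.9-fold higher number from compound 1 to compound 2 (0.59 log units; beyond the scatter). It puts (4-chlorophenyl)amino in place of 4-methylphenyl on an aromatic carbon.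

Compound 3 `COc1ccc(Nc2c(C(=O)c3cc(OC)c(OC)c(OC)c3)sc3ccccc23)cc1` changes compound 2 in one place: methoxy in place of chloro on an aromatic carbon, para to a large group (methoxy in place of chloro on an aromatic carbon). Among the compounds with values here, no measured step tests this swap. The step above replaces a different group, so it offers only a rough sense of scale, and it was modest. No clear direction can be drawn from it, so no change beyond the usual scatter is expected. The estimated change is a 1.4-fold lower number from compound 2 to compound 3 (0.13 log units; within the scatter). For compound 3 the expected value is 4000 nM, with an estimated range of 1000 nM to 14000 nM.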

Compound 3, half-maximal inhibitory concentration: 3700 nM
Compound 3: the middle estimate sits 1.1-fold (0.03 log units) above what was measured, within the range that was stated.
By their numbers in this assay, from the lowest: compound 1; then compounds 3 and 2 (each within the scatter of the next).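

In this assay, methoxy in place of chloro on this aromatic carbon, para to a large group, gives a 1.5-fold lower number from compound 2 to compound 3 (0.16 log units; within the scatter) and so leaves the reading unchanged within the scatter, even though the entering group has one more heavy atom and a hydrogen-bond acceptor. Compound 3 also tests the (4-methoxyphenyl)amino group against the 4-methylphenyl of compound 1, giving a 2.6-fold higher number from compound 1 to compound 3 (0.42 log units; beyond the scatter) as a second amino-linked compound with a higher number than compound 1, a pattern that rests only on compounds 2 and 3. No supporting measurement is available to explain either step.

From the compounds shown here alone, whether an amine, a carboxylic acid or a longer chain such as butoxy at this same carbon would also leave the number unchanged remains open. Also open, going by these compounds, is how 4-methoxyphenyl would read when attached directly to the core, without the amino link.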